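A few compounds are considered here, and "the series" means these few. Any claim that something is new, unique, unknown or untested is made for them only; others in the source may bear on it.

Compound 1: `Cc1ccc(-n2nncc2CN2C(=O)C3(C(C#N)=C(N)Oc4c3c3nc5ccccc5nc3c3ccccc43)c3ccccc32)cc1Cl` — > 50000 nM
Compound 2: `N#CC1=C(N)Oc2c(N)cc3nc4ccccc4nc3c2C12C(=O)N(Cc1cnnn1-c1cccc(Br)c1)c1ccccc12` — 18900 nM

Of the compounds shown here, two have been measured in a functional assay on A549 cells (Homo sapiens) for antiproliferative activity, read by MTT assay, with a stated time of 48 h; a lower number here means a stronger inhibitor, a higher number a weaker inhibitor. For compound 1, the value of > 50000 nM is a limit of the assay and not a number, as the limit of > 50000 nM in this assay, at which 1 of the 2 values shown sits, also notes. Compound 2, whose structure is `N#CC1=C(N)Oc2c(N)cc3nc4ccccc4nc3c2C12C(=O)N(Cc1cnnn1-c1cccc(Br)c1)c1ccccc12`, gives 18900 nM in this assay; it is the only compound of the pair with a numerical reading, so its place is simply that of the one number shown.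

The next compound to be measured is compound 3, `Cc1cc(C)cc(-n2nncc2CN2C(=O)C3(C(C#N)=C(N)Oc4c(N)cc5nc6ccccc6nc5c43)c3ccccc32)c1`. It differs from compound 2 in a single place: 3,5-dimethylphenyl in place of 3-bromophenyl on an aromatic nitrogen. The 3,5-dimethylphenyl enters where the 3-bromophenyl leaves, on an aromatic nitrogen of the five-membered ring with three nitrogens. Among the compounds with values here, no measured step of this kind is available, so the expectation rests on compound 2 alone. He expects the step of a 1.1-fold higher number from compound 2 to compound 3 (0.02 log units; within the scatter) to stay within the scatter of repeated measurements, in no particular direction. Compound 3 is therefore estimated at 20000 nM, within a range from 7000 nM to 60000 nM.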

Compound 3, half-maximal inhibitory concentration: 31200 nM
Beside the measured number, compound 3's estimate is 1.6-fold (0.19 log units) below it; low and high end bracket the measured number.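

In this assay, placing 3,5-dimethylphenyl where 3-bromophenyl stood, on the aromatic nitrogen of the five-membered ring with three nitrogens, gives a 1.7-fold higher number from compound 2 to compound 3 (0.22 log units; within the scatter). Within the data shown here, this is the first step that can be read at this position, and it shows that the two groups cannot be told apart in this read-out. The bromine is therefore not required for a reading of this size, since a phenyl ring bearing only carbon substituents serves equally well here, and nothing given here accounts for this result.

Going by these compounds, both groups are substituted phenyl rings with no hydrogen-bond donors or acceptors, so it remains open whether an amine or a carboxylic acid on that phenyl ring, or a cyclohexyl ring in its place, would move the number beyond the scatter. Compound 1 differs from the other two compounds in more than one place and its reading is a limit of the assay, so it adds no comparison at this position.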